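Fluoro for hydrogen on the benzyl ring of compound 3

A few compounds are considered here, and "the series" means these few. Any claim that something is new, unique, unknown or untested is made for them only; others in the source may bear on it.

Measured so far in a functional assay on a cell-free system (Platelet, plasma, Homo sapiens), with stated times of 4 min and 5.5 min, tested at 1 uM; a higher number here means a weaker effect of the compound at the concentration tested, a lower number a stronger effect:
compound 1 `O=C(c1ccc[n+](Cc2ccccc2)c1)N1CCN(c2ccccc2Cl)CC1` gives 89%
compound 2 `O=C(c1ccc[n+](Cc2ccccc2F)c1)N1CCN(c2ccccc2Cl)CC1` gives 85%
compound 3 `O=C(C1CCCN(Cc2ccccc2)C1)N1CCN(c2ccccc2Cl)CC1` gives 22%

Compound 3 stands lowest of the three numbers in this assay. Its nearest neighbour is compound 2, whose number lies higher by a margin beyond the scatter, and compound 1 lies higher still, also beyond the scatter. Compound 1 and compound 2 differ from each other by a number 4 percentage points lower from compound 1 to compound 2 (within the scatter).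

Compound 4 `O=C(C1CCCN(Cc2ccc(F)cc2)C1)N1CCN(c2ccccc2Cl)CC1` is not yet measured. Compared with compound 3 it carries fluoro in place of hydrogen on an aromatic carbon.

Among the compounds with values here, the one measured step that bears on this change is the step from compound 1 to compound 2, which is the same kind of change, fluoro in place of hydrogen on an aromatic carbon, and which stayed within the scatter. On that basis no step beyond the scatter is expected in this assay. The step from compound 3 to compound 4 is therefore estimated at no change at the digits printed from compound 3 to compound 4 (within the scatter), and compound 4 is expected to give 22%, with a range from 8% to 40%.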

Compound 4, a percentage reported as activity, at one concentration (the size of the read-out at that concentration, not a potency): 40%
The estimate for compound 4 lay 18 percentage points below the measured number; the range from low to high includes it.
By their numbers in this assay, from the lowest: compound 3; then compound 4; then compounds 2 and 1 (each within the scatter of the next).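

In this assay, fluoro in place of hydrogen on the benzyl ring has a readable cost on the core of compound 3, with a number 18 percentage points higher from compound 3 to compound 4 (beyond the scatter), which means a weaker effect at the concentration tested. The size of this change therefore does not carry over from one core to the other: the same change on two cores in this assay, a number 4 percentage points lower (within the scatter) from compound 1 to compound 2 and a number 18 percentage points higher (beyond the scatter) from compound 3 to compound 4, 22 percentage points apart, beyond the scatter of two such steps. The fluoro of compound 4 stands para to a large group, whereas that of compound 2 stands elsewhere on its ring, so core and place differ together between the two steps.

Going by these compounds, it remains open whether the weaker effect belongs to fluoro itself or to any group at this place, as a chloro, methyl or methoxy group there could show. On these data alone, it also remains open how fluoro would behave on the core of compound 3 at the ring place it holds in compound 2.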